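The compounds below may be only part of what the source reports. "The series", "measured", "known", "first", "only" and "open" are said of these compounds alone.

Values measured in an ADME assay on L6 cells (Rattus norvegicus) for cytotoxicity; a higher number here means a weaker inhibitor, a lower number a stronger inhibitor:
- Compound 1 `O=C(Nc1c(O)cccc1-c1nc2c(C(=O)O)cccc2o1)c1ncccc1F`: 204000 nM
- Compound 2 `O=C(Nc1c(O)cccc1-c1nc2c(C(=O)O)cccc2o1)c1cccnc1`: 240000 nM
- Compound 3 `O=C(Nc1c(O)cccc1-c1nc2c(C(=O)O)cccc2o1)c1cnccn1`: 94400 nM

These three compounds share one core and differ only in the group on the carbonyl carbon of the amide. Within the data shown here, compound 3, at 94400 nM, has the lowest number of the three, which makes it the strongest inhibitor in this assay so far.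

The next compound is compound 4 `O=C(Nc1c(O)cccc1-c1nc2c(C(=O)O)cccc2o1)c1cc2ccccc2[nH]1`, which carries 1H-indol-2-yl in place of pyrazin-2-yl on a carbonyl carbon. In the measured compounds, this place only ever holds one six-membered aromatic ring, so the new group goes beyond what has been tested.

Three measured steps at this same place offer a guide. One is small, a 1.2-fold higher number from compound 1 to compound 2 (0.07 log units; within the scatter). The two that reach compound 3 are modest, a 2.2-fold lower number from compound 1 to compound 3 (0.33 log units; beyond the scatter) and a 2.5-fold lower number from compound 2 to compound 3 (0.41 log units; beyond the scatter). Swapping the group here has so far moved the number only a little, so a similarly small change is expected, though its direction is uncertain and the larger group widens the range.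

The expected step is a 1.3-fold lower number from compound 3 to compound 4 (0.13 log units; within the scatter). For compound 4 the estimated value is 70000 nM, with an expected range from 25000 nM to 200000 nM.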

Compound 4, half-maximal inhibitory concentration: 212000 nM
Estimate against measurement, compound 4: 3.0-fold (0.48 log units) below; measured number outside the range, above it.
By their numbers in this assay, from the lowest: compound 3; then compounds 1, 4 and 2 (each within the scatter of the next).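

Placing 1H-indol-2-yl on the carbonyl carbon, a group with two aromatic rings instead of one, gives a 2.2-fold higher number from compound 3 to compound 4 (0.35 log units; beyond the scatter) in this assay. The other two steps show no separation from the earlier groups, with a 1.1-fold lower number from compound 2 to compound 4 (0.05 log units; within the scatter) and a 1.0-fold higher number from compound 1 to compound 4 (0.02 log units; within the scatter). Among these compounds, this means that the larger group, which is also the first here to carry a hydrogen-bond donor, falls in the same band as the 3-fluoropyridin-2-yl and pyridin-3-yl groups, leaving compound 3 alone as the strongest inhibitor of the four, with pyrazin-2-yl the only group that stands apart. No measurement shown here explains why pyrazin-2-yl stands apart.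

The four compounds cannot separate any contribution of the indole's second ring from that of its hydrogen-bond donor, since the two enter together in compound 4. Every group shown at this place is aromatic, so how an amine or a simple alkyl chain on the carbonyl carbon would behave in this assay remains open.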